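A few compounds are considered here, and "the series" means these few. Any claim that something is new, unique, unknown or untested is made for them only; others in the source may bear on it.

Measured compounds in a functional assay on HSC-2 cells (Homo sapiens) for cytotoxicity, with a stated time of 24 h; on this read-out lower numbers stand for higher toxicity in this test and higher numbers for lower toxicity in this test:
compound 1, `O=C1/C(=C/c2ccc(F)cc2)CCC/C1=C\c1ccccc1[N+](=O)[O-]`, gives 2700 nM
compound 2, `O=C1/C(=C/c2ccc(Cl)cc2)CCC/C1=C\c1ccccc1[N+](=O)[O-]`, gives 3700 nM
compound 3, `O=C1/C(=C/c2ccc(F)cc2)CCC/C1=C\c1ccc([N+](=O)[O-])cc1`, gives 19000 nM

Compound 1 and compound 2 share one core and differ in one place, (chloro in place of fluoro on an aromatic carbon). In this assay this change made a 1.4-fold higher number from compound 1 to compound 2 (0.14 log units; within the scatter), so the two compounds read as equivalent within the scatter.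

Compound 3 carries the other core. The difference between the two cores is not broken down here; compound 1 and compound 3 have the same atoms joined differently. Compound 3 has the highest number of the three measured, lying beyond the scatter from both compound 2 and compound 1.

Compound 4, `O=C1/C(=C/c2ccc(Cl)cc2)CCC/C1=C\c1ccc([N+](=O)[O-])cc1`, has not been measured in this assay. It differs from compound 3 by chloro in place of fluoro on an aromatic carbon, which is the same change as that from compound 1 to compound 2, on the same place in the same words. Across the compounds shown the change occurs twice, once measured and once to be measured.

Among the measured compounds shown here, the expectation for compound 4 rests on the one measured instance of this change: because a 1.4-fold higher number from compound 1 to compound 2 (0.14 log units; within the scatter) stayed within the scatter, the step from compound 3 to compound 4 is expected to be a 1.4-fold higher number from compound 3 to compound 4 (0.14 log units; within the scatter), likewise small. Whether the core of compound 3 carries the change in the same way is not shown by the data, so the range is kept wide. For compound 4 the estimated value in this assay is 26000 nM, with a range from 11000 nM to 60000 nM.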

Compound 4, half-maximal cytotoxic concentration: 1500 nM
Compound 4: middle estimate off by 17-fold (1.24 log units), on the high side; measured number below the stated range.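

In this assay, chloro in place of fluoro does not carry over from one core to the other with a step of the same size: the same change on two cores in this assay, a 1.4-fold higher number (0.14 log units; within the scatter) from compound 1 to compound 2 and a 13-fold lower number (1.10 log units; beyond the scatter) from compound 3 to compound 4, 17-fold (1.24 log units) apart, beyond the scatter of two such steps

On the core of compound 3, the change from 4-fluorophenyl to 4-chlorophenyl gives a 13-fold lower number from compound 3 to compound 4 (1.10 log units; beyond the scatter), whereas on the core of compound 1 it stayed within the scatter, and a small step on one of these two cores is therefore no guide to the size of the step on the other. This shows that the effect of this change on the read-out depends on the core within these four compounds; it does not show which feature of the core is responsible, and with one step on each core it gives no rule for any further core.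

Only fluoro and chloro appear on this aromatic carbon, which leaves open whether bromo, methyl or methoxy in the same place would give a small step on the core of compound 1 and a large one on the core of compound 3. Also open, as far as these compounds go, is whether the large step on the core of compound 3 would persist if an amine or a carboxylic acid took the place of the nitro group.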